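From fluoro to methyl on the benzyl group

The source may hold more compounds than are shown below. What is called first, only, known or untested is meant among the compounds shown, and "the series" means these compounds.

- compound 1 `COc1ccc(S(=O)(=O)Oc2ccccc2/C=C(\C#N)C(=O)Nc2nnc(-c3cccs3)s2)cc1`: 4750 nM
- compound 2 `COc1ccc(Cc2nnc(NC(=O)/C(C#N)=C/c3ccccc3OS(=O)(=O)c3ccc(OC)cc3)s2)cc1`: 840 nM
- compound 3 `COc1ccc(S(=O)(=O)Oc2ccccc2/C=C(\C#N)C(=O)Nc2nnc(Cc3ccc(F)cc3)s2)cc1`: 1210 nM

These three compounds were tested in a functional assay on RS4-11 cells (Homo sapiens) for inhibition, read by CCK-8 assay, with a stated time of 48 h; a lower number here means a stronger inhibitor, a higher number a weaker inhibitor. Compound 3 cannot be separated from compound 2, since fluoro in place of methoxy gives a step within the scatter (a 1.4-fold higher number from compound 2 to compound 3 (0.16 log units; within the scatter)). Compound 3 stands clearly lower than compound 1 (a 3.9-fold lower number from compound 1 to compound 3 (0.59 log units; beyond the scatter)).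

The next compound, compound 4 `COc1ccc(S(=O)(=O)Oc2ccccc2/C=C(\C#N)C(=O)Nc2nnc(Cc3ccc(C)cc3)s2)cc1`, has methyl in place of fluoro on an aromatic carbon, para to a large group (methyl in place of fluoro on an aromatic carbon).

The closest guide is the methoxy-to-fluoro step above, made at this same place, and it stayed within the scatter. The larger steps (a 5.7-fold lower number from compound 1 to compound 2 (0.75 log units; beyond the scatter); a 3.9-fold lower number from compound 1 to compound 3 (0.59 log units; beyond the scatter)) came from replacing thiophen-2-yl with a whole benzyl group, a much bigger change made elsewhere on the structure. Going by the values given here, with only one step at this place, the evidence is thin, but no step beyond the scatter is expected in this assay. The estimated change is small (a 1.2-fold lower number from compound 3 to compound 4 (0.08 log units; within the scatter)). For compound 4 the expected value is 1000 nM, with an estimated range from 450 nM to 2200 nM.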

Compound 4, half-maximal inhibitory concentration: 1010 nM
Estimate against measurement, compound 4: 1.0-fold (0.00 log units) below; the range from low to high includes it.
By their numbers in this assay, from the lowest: compounds 2, 4 and 3 (each within the scatter of the next); then compound 1.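

Methyl in place of fluoro at this place, an aromatic carbon para to a large group, gives no readable change in this assay (a 1.2-fold lower number from compound 3 to compound 4 (0.08 log units; within the scatter)), and methyl in place of methoxy gives none either (a 1.2-fold higher number from compound 2 to compound 4 (0.08 log units; within the scatter)). Where one step at this place stood before, there are now two, so methoxy, fluoro and methyl cannot be told apart here, and 4-methylbenzyl in place of thiophen-2-yl still gives a clear drop in the number (a 4.7-fold lower number from compound 1 to compound 4 (0.67 log units; beyond the scatter)), as the other two benzyl groups did. Nothing measured here explains why these three groups read alike.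

As far as these compounds go, whether that sameness would hold for an amine, a carboxylic acid or a longer chain at this place stays open. Also open, from the compounds shown here alone, is whether the drop from compound 1 comes from the ring or from the link, which a thiophen-2-ylmethyl group could help separate.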